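A few compounds are considered here, and "the series" means these few. Any claim that something is new, unique, unknown or untested is made for them only; others in the source may bear on it.

Measured in a functional assay on SK-BR-3 cells (Homo sapiens) for antiproliferative activity; on this read-out lower numbers stand for stronger inhibition and higher numbers for weaker inhibition:
- Compound 1 `CC(C)=CCc1cc(C(=O)Nc2cc3ccc(OCC4CCN(C)C4)c(C)c3oc2=O)ccc1O`: 920 nM
- Compound 2 `CC(C)=CCc1cc(C(=O)Nc2cc3ccc(OCCCNC(C)C)c(C)c3oc2=O)ccc1O`: 750 nM

Compound 2, at 750 nM, cannot be told apart from compound 1 in this assay. Compound 3 `CC(C)=CCc1cc(C(=O)Nc2cc3ccc(OCCCNCC(=O)O)c(C)c3oc2=O)ccc1O` carries carboxymethyl in place of isopropyl on an amine nitrogen. For the measured compounds named here, the only measured step, a 1.2-fold lower number from compound 1 to compound 2 (0.09 log units; within the scatter), exchanged one amine side chain for another and involved no carboxymethyl, so it offers only a loose guide. Going by the values given here, no measured compound tests this group, which leaves both the size and the direction uncertain. A modest step is expected, cautiously toward weaker inhibition: a 2.7-fold higher number from compound 2 to compound 3 (0.43 log units; beyond the scatter). For compound 3 the estimate is 2000 nM, with an expected range of 600 nM to 8000 nM.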

Compound 3, half-maximal inhibitory concentration: 7570 nM
Compound 3: middle estimate off by 3.8-fold (0.58 log units), on the low side; the measured number falls inside the stated range.
By their numbers in this assay, from the lowest: compounds 2 and 1 (each within the scatter of the next); then compound 3.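

In this assay, the amine nitrogen of this side chain does not accept every group equally: carboxymethyl in place of isopropyl gives a 10-fold higher number from compound 2 to compound 3 (1.00 log units; beyond the scatter) and moves clearly beyond the scatter, unlike the earlier exchange of amine side chains. The comparison with the other side chain agrees, with an 8.2-fold higher number from compound 1 to compound 3 (0.92 log units; beyond the scatter) as the result. No available evidence gives a reason for this loss of inhibition. A methyl ester or a primary amide in place of the carboxylic acid could show whether the acid itself matters. On these data alone, a longer chain carrying the acid remains open too.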